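Removing the Linking Methylene: Predicting Compound 4

The source may hold more compounds than are shown below. What is called first, only, known or untested is meant among the compounds shown, and "the series" means these compounds.

Measured so far:
- compound 1, `CO[C@H]1CC[C@@H](Nc2cc(NCc3cnccc3C(F)(F)F)ncc2C#N)CC1`: 58 nM
- compound 2, `CO[C@H]1CC[C@@H](CNc2cc(NCc3cnccc3C(F)(F)F)ncc2C#N)CC1`: 70 nM
- compound 3, `CO[C@H]1CC[C@H](CNc2cc(NCc3cnccc3C(F)(F)F)ncc2C#N)CC1`: 330 nM

In an assay on isolated protein for inhibition of protein kinase C theta type (Homo sapiens), read by TR-FRET, with a stated time of 2 h (a higher number here means a weaker inhibitor, a lower number a stronger inhibitor), compound 3 gives the highest number of the three, with compound 2 nearest and compound 1 furthest, so compound 3 is the weakest inhibitor shown. Compound 4, `CC1(C)C[C@@H](Nc2cc(NCc3cnccc3C(F)(F)F)ncc2C#N)CC[C@H]1O`, differs from compound 3 in one place: 4-hydroxy-3,3-dimethylcyclohexyl in place of (4-methoxycyclohexyl)methyl on a nitrogen on an aromatic ring.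

Among the measured compounds shown here, two measured steps bear on this. From compound 1 to compound 3 the change was a 5.7-fold higher number from compound 1 to compound 3 (0.76 log units; beyond the scatter), and from compound 2 to compound 3 it was a 4.7-fold higher number from compound 2 to compound 3 (0.67 log units; beyond the scatter); the latter rests on (the fact that compounds 2 and 3 differ only in the configuration as drawn). Both show that compound 3 sits on the weak side of a ring that carries an added methylene and a changed configuration. For the measured compounds named here, compound 4 returns to a cyclohexyl group set directly on the nitrogen, as in compound 1, while the 4-methoxy becomes a 4-hydroxy with two added methyl groups; no measured pair covers that second part.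

The step from compound 3 to compound 4 is therefore expected to be a 4.1-fold lower number from compound 3 to compound 4 (0.62 log units; beyond the scatter), a lower number. Compound 4 is estimated at 80 nM, with a range from 25 nM to 300 nM.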

Compound 4, half-maximal inhibitory concentration: 120 nM
For compound 4 the middle estimate is 1.5-fold (0.18 log units) below the measured one; low and high end bracket the measured number.
By their numbers in this assay, from the lowest: compounds 1, 2 and 4 (each within the scatter of the next, the first and the last beyond it); then compound 3.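

Among the compounds shown here, until now, every group on this nitrogen carried a 4-methoxy, so compound 4 is the first to show that a ring with a 4-hydroxy, two added methyl groups and a hydrogen-bond donor is tolerated in this assay: the data give a 2.8-fold lower number from compound 3 to compound 4 (0.44 log units; beyond the scatter) and a 1.7-fold higher number from compound 2 to compound 4 (0.23 log units; within the scatter). Set directly on the nitrogen, as in compound 1, the new group gives only a modest shift, a 2.1-fold higher number from compound 1 to compound 4 (0.32 log units; beyond the scatter), so the methoxy is not required for a number in this range. Nothing at hand explains these steps, and the hydroxy and the two methyl groups arrive together, so their separate shares cannot be told.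

The compounds shown leave open how the hydroxy would behave without the two methyl groups, and how the mirror-image form of the new group would compare. They also leave open whether an amine or a carboxylic acid in place of that hydroxy would give a similar number.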